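Removing the bromo group from the strongest analogue

The compounds below may be only part of what the source reports. "The series", "measured", "known", "first", "only" and "open" are said of these compounds alone.

Of the compounds shown here, three built on one shared core have been tested in a functional assay on MDA-MB-468 cells (Homo sapiens) for cytotoxicity, read by sulforhodamine B assay, with a stated time of 48 h; a lower number here means a stronger inhibitor of growth, a higher number a weaker inhibitor of growth. Compound 1 `CCN(CC)CN1C(=O)/C(=N\c2nc3ccc(C)cc3s2)c2ccccc21` gives 63500 nM. Compound 2 `Cc1ccc2nc(/N=C3\C(=O)N(CN4CCCCC4)c4ccccc43)sc2c1` gives 65600 nM. Among the measured compounds shown here, the only step measured between them, a 1.0-fold higher number from compound 1 to compound 2 (0.01 log units; within the scatter), swaps the amine on the saturated chain carbon bound to the ring nitrogen and leaves the number essentially where it was. Compound 3 `Cc1ccc2nc(/N=C3\C(=O)N(CN(C)C)c4cccc(Br)c43)sc2c1` gives 27400 nM, the lowest of the three; its gaps to compound 1 and to compound 2 both lie beyond the scatter, so compound 3 is the strongest growth inhibitor of the set.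

Compound 4 `Cc1ccc2nc(/N=C3\C(=O)N(CN(C)C)c4ccccc43)sc2c1` differs from compound 3 in one place: hydrogen in place of bromo on an aromatic carbon, the carbon belonging to a fused system of two rings. For the measured compounds named here, no measured step touches this position, so nothing bears on it directly. Indirectly, compounds 1 and 2 lack the bromo group and sit higher than compound 3, while the amine exchange between them changed little, and compound 4 likewise lacks bromo and carries a dimethylamino. The account therefore expects a step of a 2.1-fold higher number from compound 3 to compound 4 (0.33 log units; beyond the scatter) toward a higher number for compound 4. Compound 4 is estimated at 58000 nM, within a range from 30000 nM to 110000 nM.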

Compound 4, concentration for 50% growth inhibition: 35500 nM
For compound 4 the middle estimate is 1.6-fold (0.21 log units) above the measured one; measured number inside the range.
By their numbers in this assay, from the lowest: compounds 3, 4, 1 and 2 (each within the scatter of the next, the first and the last beyond it).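

In this assay, among the compounds shown here, the exchange of bromo for hydrogen on this aromatic carbon, ortho to a fused ring, gives a 1.3-fold higher number from compound 3 to compound 4 (0.11 log units; within the scatter), so the first direct reading of the position shows no difference that can be told from the scatter. For the compounds shown here, the same compound also gives the first reading of dimethylamino on the saturated chain carbon, with a 1.8-fold lower number from compound 2 to compound 4 (0.27 log units; within the scatter) and a 1.8-fold lower number from compound 1 to compound 4 (0.25 log units; within the scatter), so the dimethylamino, piperidin-1-yl and diethylamino compounds without bromo all stand within the scatter of one another in this assay. No measurement is at hand that would explain these readings.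

On these data alone, what a chloro, a methoxy or a carboxylic acid on this aromatic carbon would do to the number remains open, as does whether any group there could move it beyond the scatter. It is also open whether a morpholin-4-yl or a piperazin-1-yl on the chain carbon would stay within the scatter of the three amines shown, and whether bromo would give the same small step with piperidin-1-yl or diethylamino in place of dimethylamino.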